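Ethyl to a Difluorinated Ring: Stability Outlook

The source may hold more compounds than are shown below. What is called first, only, known or untested is meant among the compounds shown, and "the series" means these compounds.

Measured compounds:
compound 1 `CCCN(C[C@H]1Cc2c(cccc2N2CCNCC2)CN1)[C@H]1CCCc2cccnc21`, 100%
compound 2 `Cc1cnc(CN(C)C[C@H]2Cc3c(cccc3N3CCNCC3)CN2)c(C)c1`, "not determined" (no result reported)
compound 3 `CN(C[C@H]1Cc2c(cccc2N2CCN(c3cccc(C(F)(F)F)c3)CC2)CN1)[C@H]1CCCc2cccnc21`, 90.3%

The three compounds share a common core and were examined in an ADME assay on microsomes from liver (Homo sapiens) for metabolic stability, read by LC-MS, with a stated time of 10 min; on this read-out lower numbers stand for a less stable compound and higher numbers for a more stable compound. Compound 1 gives 100%, the higher of the two numbers available, while compound 3 gives 90.3%; the gap between these two lies within the usual scatter, so no order between them can be claimed. For compound 2 the result is "not determined" (no result reported), so it offers no number to compare against.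

The step of interest leads from compound 1 to compound 4 `FC1(F)CCC(CN(C[C@H]2Cc3c(cccc3N3CCNCC3)CN2)[C@H]2CCCc3cccnc32)CC1`. The change is 4,4-difluorocyclohexyl in place of ethyl on a saturated chain carbon bound to an amine nitrogen. For the measured compounds named here, no step between two measured compounds that differ in a single place is available, so the expected size of this step rests only on the value of compound 1. Since compound 1 stands at 100%, the read-out has no room to rise; any movement could only be downward. The expectation is a small step, a number 12 percentage points lower from compound 1 to compound 4 (beyond the scatter), most likely within the scatter and at worst a modest loss. Compound 4 is therefore estimated at 88%, with a range from 65% to 100%.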

Compound 4, percent of the compound remaining: 68.6%
For compound 4 the middle estimate is 19.4 percentage points above the measured one, and the stated range covers the measured number.
By their numbers in this assay, from the lowest: compound 4; then compounds 3 and 1 (each within the scatter of the next).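

In this assay, putting 4,4-difluorocyclohexyl in place of ethyl on a saturated chain carbon bound to an amine nitrogen gives a large step, a number 31.4 percentage points lower from compound 1 to compound 4 (beyond the scatter), and this is the first pair shown that differs in one place only. For the compounds shown here, it shows that the read-out is sensitive to what this position carries, since the earlier values gave no way to isolate any single change, though with only one step this says nothing about other groups there. No evidence is available on what lies behind this drop.

The change brings in a ring and fluorine atoms together and also enlarges the group, so the pair cannot show which of these differences matters for the result. A plain cyclohexyl ring without fluorine, or a longer open chain such as butyl, at the same place would help separate these differences, and the compounds shown leave open whether either would stand closer to compound 1 or to compound 4.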